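A few compounds are considered here, and "the series" means these few. Any claim that something is new, unique, unknown or untested is made for them only; others in the source may bear on it.

Of the compounds shown here, three built on a shared core have been measured in an assay on HeLa cells for displacement of a labelled ligand from adenosine receptor A3 (Homo sapiens), with a stated time of 180 min, tested at 10 uM; on this read-out lower numbers stand for less inhibition and higher numbers for more inhibition at the one concentration tested (going by the name of the read-out). Compound 1 `CC(=O)C1=C(C)NC(=O)NC1c1ccco1` gives 14%, compound 2 `CCOC(=O)C1=C(C(F)(F)F)NC(=O)NC1c1ccco1` gives 2%, and compound 3 `CC1=C(C(=O)OC(C)C)C(c2ccoc2)NC(=O)N1` gives 3%. Compound 3 thus sits within the scatter of compound 2, while its gap to compound 1 lies beyond the scatter, with compound 1 the higher of the two.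

Compound 4 `CC1=C(C(=O)OC(C)C)C(c2ccoc2)NC(=O)N1C` differs from compound 3 by methyl in place of hydrogen on an amide-type nitrogen in a ring. Among the compounds with values here, no measured pair shows this change, so its effect is not known. Because compound 3 gives only 3%, the small change is expected to leave the read-out near that level. The step of a number 2 percentage points higher from compound 3 to compound 4 (within the scatter) is expected to stay within the scatter, in no clear direction. Compound 4 is therefore estimated at 5%, with a range from 0% to 15%.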

Compound 4, a percentage reported as inhibition, at one concentration (the size of the read-out at that concentration, not a potency): 1%
Compound 4: middle estimate off by 4 percentage points, on the high side, within the range that was stated.
By their numbers in this assay, from the lowest: compounds 4, 2 and 3 (each within the scatter of the next); then compound 1.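

Methyl in place of hydrogen on an amide-type nitrogen in a ring, the only change at this position that can be read in this assay, amounts to a number 2 percentage points lower from compound 3 to compound 4 (within the scatter) and so leaves the read-out at its low level. With the isopropoxycarbonyl and furan-3-yl groups in place, this nitrogen therefore takes a methyl without a readable change, although a start this low leaves little room for any fall. Nothing available accounts for this step.

From the compounds shown here alone, whether a longer chain or a benzyl group on this nitrogen would raise the read-out remains open. So does whether methyl here would act the same way on the core of compound 1, which gives 14%.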